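This account rests on a few compounds, and the source may have more. Where it says the series, first, only, none or still open, it means among the compounds named here.

Measured compounds:
Compound 1, `CCn1c(C(=O)NCCN(C)C)ccc1C(CC)(CC)c1ccc(OCCC(O)(CC)CC)c(C)c1`: in a functional assay on HepG2 cells (Homo sapiens) for antiproliferative activity, read by MTT assay, with a stated time of 48 h (a higher number here means a weaker inhibitor, a lower number a stronger inhibitor), compound 1 gives 240 nM.
Compound 2, `C=CCN(C)C(=O)c1ccc(C(CC)(CC)c2ccc(OCCC(O)(CC)CC)c(C)c2)n1CC`: in this assay compound 2 gives > 50000 nM, which is a limit of the assay and not a number.

Among the compounds with values here, compound 1 therefore stands as the one real number; the other entry sits at the limit (the limit of > 50000 nM in this assay, at which 1 of the 2 values shown sits). Within the data shown here, the single measured step is an at least 200-fold higher number from compound 1 to compound 2 (2.31 log units; beyond the scatter), a large loss on replacing the (2-(dimethylamino)ethyl)amino group with allyl(methyl)amino.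

Compound 3, `C#CCCOC(=O)c1ccc(C(CC)(CC)c2ccc(OCCC(O)(CC)CC)c(C)c2)n1CC`, differs from compound 1 by (but-3-yn-1-yl)oxy in place of (2-(dimethylamino)ethyl)amino on a carbonyl carbon. Among the measured compounds shown here, the same (2-(dimethylamino)ethyl)amino group that is lost in the step to compound 2 is lost here too, with (but-3-yn-1-yl)oxy entering instead, so the step from compound 1 to compound 2 is the one measured step that bears on this change, and it was large. A step of comparable size and the same direction is expected, a 130-fold higher number from compound 1 to compound 3 (2.10 log units; beyond the scatter), so compound 3 is estimated to be a much weaker inhibitor than compound 1, with a fair chance that this assay again reports only a limit. The expected value for compound 3 is 30000 nM, within 3000 nM to 100000 nM.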

Compound 3, half-maximal inhibitory concentration: > 50000 nM
Compound 3 was reported as a limit; the forecaster's own chance of this, stated with the estimate: 55%; middle value at least 1.6-fold (0.22 log units) away from the limit.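

In this assay, (but-3-yn-1-yl)oxy in place of (2-(dimethylamino)ethyl)amino on the carbonyl carbon gives an at least 200-fold higher number from compound 1 to compound 3 (2.31 log units; beyond the scatter), so the loss no longer rests on a single replacement group. It now appears with an ester as well as with the amide of allyl(methyl)amino, and both entering groups lack the dimethylamino end and the amide hydrogen of compound 1. Compound 2 and compound 3 are both reported as limits, so the step between them cannot be read and the two cannot be ordered: the limit of > 50000 nM in this assay, at which 2 of the 3 values shown sit.

The dimethylamino end and the amide hydrogen change together in these compounds, so the shown data do not separate them: (2-hydroxyethyl)amino would keep the amide hydrogen without the amine, and a (2-(dimethylamino)ethyl)oxy ester would keep the amine without the amide hydrogen. From the compounds shown here alone, whether a longer chain such as (3-(dimethylamino)propyl)amino, or a cyclic amine such as a morpholine at the chain end, can match compound 1 at 240 nM also stays open.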